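This account rests on a few compounds, and the source may have more. Where it says the series, first, only, none or still open, it means among the compounds named here.

Compound 1 `COc1ccc2nc(C)cc(NCc3ccc(C)cc3)c2c1`: 18800 nM
Compound 2 `COc1ccc2nc(C)cc(NCc3cccc(F)c3)c2c1`: 11300 nM

Going by the values given here, in a functional assay on MCF-10A cells (Homo sapiens) for antiproliferative activity, with a stated time of 48 h (a lower number here means that less compound is needed, a higher number that more compound is needed for the effect), compound 1 at 18800 nM stands within the scatter of compound 2, the only other measured compound. Compound 3 `COc1ccc(CNc2cc(C)nc3ccc(OC)cc23)cc1` is unmeasured and differs from compound 1 by methoxy in place of methyl on an aromatic carbon, para to a large group. Among the compounds with values here, one measured step bears on this, as it also alters a substituent on that ring, exchanging 4-methylphenyl for 3-fluorophenyl. That step, a 1.7-fold lower number from compound 1 to compound 2 (0.22 log units; within the scatter), stayed small. Within the data shown here, no measured compound carries the methoxy group, so the evidence is thin. On the strength of the step to compound 2, no change beyond the scatter is expected in this assay. The estimated change is a 1.2-fold lower number from compound 1 to compound 3 (0.07 log units; within the scatter). Compound 3 is expected at about 16000 nM, with an estimated range of 7000 nM to 36000 nM.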

Compound 3, half-maximal effective concentration: 7000 nM
Compound 3: the middle estimate sits 2.3-fold (0.36 log units) above what was measured; the measured number falls inside the stated range.
By their numbers in this assay, from the lowest: compounds 3, 2 and 1 (each within the scatter of the next, the first and the last beyond it).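

In this assay, methoxy in place of methyl on an aromatic carbon, para to a large group, gives a 2.7-fold lower number from compound 1 to compound 3 (0.43 log units; beyond the scatter) and so moves the number modestly but beyond the scatter. Going by these compounds alone, the earlier change on this ring, a 1.7-fold lower number from compound 1 to compound 2 (0.22 log units; within the scatter), replaced the whole 4-methylphenyl with 3-fluorophenyl and stayed within the scatter, so compound 3 is the first sign that this position can respond at all, and that a single exchange at it is enough. Nothing measured accounts for this step.

The compounds shown leave open whether the response belongs to methoxy itself, since ethoxy, hydroxyl or an amine at the same place are not among them. A single step also cannot say whether the lower number would hold on a ring carrying fluorine instead.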